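The source may hold more compounds than are shown below. What is called first, only, known or untested is meant among the compounds shown, and "the series" means these compounds.

In an ADME assay on HEL cells (Homo sapiens) for cytotoxicity, with a stated time of 3 days (a higher number here means that more compound is tolerated, a lower number that less compound is tolerated), compound 1 `CC(C)CC1(Cc2ccccc2)OS(=O)(=O)C=C1OCc1ccccc1` reaches only a limit, >= 80000 nM. Compound 2 `CCC1(Cc2ccccc2)OS(=O)(=O)C=C1OCc1ccccc1` likewise reaches only a limit in this assay, >= 50000 nM. Going by the values given here, the single measured step, a step that the two limits leave unreadable from compound 1 to compound 2, therefore cannot be read; both measured values sit at limits, the limit of >= 50000 nM in this assay, at which 1 of the 2 values shown sits, and (the limit of >= 80000 nM in this assay, at which 1 of the 2 values shown sits). Compound 3 `O=S1(=O)C=C(OCc2ccccc2)C(Cc2ccccc2)(Cc2ccccc2)O1` carries the change (phenyl in place of methyl on a saturated chain carbon bound to a saturated ring carbon). No readable step bears on this change, so no shift beyond the scatter is expected in this assay, and a further limit rather than a number is the most probable outcome. Compound 3 is expected near 50000 nM, between 25000 nM and 100000 nM, an expected step of a number no higher from compound 2 to compound 3 (the limit leaves the size open).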

Compound 3, minimum cytotoxic concentration: 200000 nM
Estimate against measurement, compound 3: 4.0-fold (0.60 log units) below; the measured number lies above the stated range.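

Compound 1 and compound 2 stand only at limits, and the steps from each of them to compound 3 cannot be read. As far as these compounds go, how far phenyl in place of methyl or isopropyl shifts the tolerated concentration stays open.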